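This account rests on a few compounds, and the source may have more. Where it says the series, first, only, none or still open, it means among the compounds named here.

In an ADME assay on cells (Peritoneal macrophage, Mus musculus) for cytotoxicity, read by CCK-8 assay, with a stated time of 24 h (a higher number here means that more compound is tolerated, a lower number that less compound is tolerated), compound 1 (`COc1ccc(S(=O)(=O)N(CC(N)=O)c2ccc(N(CC(N)=O)S(=O)(=O)c3ccc(SCCCCN=C=S)cc3)c3ccccc23)cc1`) gives > 10000 nM as a limit of the assay, not a number. Compound 2 (`COc1ccc(S(=O)(=O)N(CC(N)=O)c2ccc(N(CC(N)=O)S(=O)(=O)c3ccc(SCCCCCN=C=S)cc3)c3ccccc23)cc1`) gives > 10000 nM as a limit too. Compound 3 (`COc1ccc(S(=O)(=O)N(CC(N)=O)c2ccc(N(CC(N)=O)S(=O)(=O)c3ccc(SCCOCCOCCN=C=S)cc3)c3ccccc23)cc1`) gives > 10000 nM as a limit also, so it has no number of its own. All results so far sit at one value (the limit of > 10000 nM in this assay, at which 3 of the 3 values shown sit) and give no order within the series.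

Compound 4 (`COc1ccc(S(=O)(=O)N(CC(N)=O)c2ccc(N(CC(N)=O)S(=O)(=O)c3ccc(S(=O)(=O)CCN=C=S)cc3)c3ccccc23)cc1`) differs from compound 3 on an aromatic carbon of a six-membered aromatic ring of carbon only, para to a large group (a group of 8 heavy atoms (3 carbon, 1 nitrogen, 2 oxygen, 2 sulfur; no ring) in place of a group of 12 heavy atoms (7 carbon, 1 nitrogen, 2 oxygen, 2 sulfur; no ring), on an aromatic carbon). The measured steps that bear on this change all alter the same chain: (a step that the two limits leave unreadable from compound 1 to compound 2), (a step that the two limits leave unreadable from compound 1 to compound 3) and (a step that the two limits leave unreadable from compound 2 to compound 3). None of them yields a size. No step beyond the scatter is therefore expected in this assay, and another limit is the likeliest report, though this expectation is weakly founded. The expected step is (a step that the limit leaves unreadable from compound 3 to compound 4). Compound 4 is estimated at 12000 nM with an expected range from 5000 nM to 30000 nM in this read-out.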

Compound 4, half-maximal cytotoxic concentration: > 10000 nM
Compound 4: no number, only a limit (the forecaster's own chance of this, stated with the estimate: 75%); the middle value lies beyond the limit too.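

Among the compounds shown here, compound 4 gives only a limit in this assay, so no step between it and compound 1, compound 2 or compound 3 can be read: the limit of > 10000 nM in this assay, at which 4 of the 4 values shown sit. Whether the chain changes tolerance at all in this assay stays open, as does where any of these compounds lies beyond that limit.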